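The source may hold more compounds than are shown below. What is called first, only, known or untested is meant among the compounds shown, and "the series" means these compounds.

Of the compounds shown here, two sharing one core have been tested in a functional assay on the whole organism for inhibition, with Rattus norvegicus as the target, at a dose of 0.3 mg/kg by the intravenous route; on this read-out higher numbers stand for a stronger effect at the one dose given and lower numbers for a weaker effect. Compound 2 `CCCc1nn(Cc2ccccc2)c(C(=O)O)c1Cc1ccc(-c2ccccc2-c2nn[nH]n2)cc1` gives 95%, the highest of the two numbers. Compound 1 `CCCCc1nn(-c2ccccc2Cl)c(C(=O)O)c1Cc1ccc(-c2ccccc2-c2nn[nH]n2)cc1` gives 73%, a number that lies beyond the scatter below compound 2. Compound 3 `CCCc1nn(-c2ccccc2C(F)(F)F)c(C(=O)O)c1Cc1ccc(-c2ccccc2-c2nn[nH]n2)cc1` differs from compound 2 in one place: 2-(trifluoromethyl)phenyl in place of benzyl on an aromatic nitrogen. Among the compounds with values here, no measured pair isolates this change, so the step from compound 2 to compound 3 is estimated at a number 17 percentage points lower from compound 2 to compound 3 (beyond the scatter), a modest fall in this assay. Compound 3 is therefore expected to give about 78%, within a range from 55% to 95%.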

Compound 3, a percentage reported as inhibition, in the whole organism at one dose (the size of the read-out at that dose, not a potency): 77%
For compound 3 the middle estimate is 1 percentage points above the measured one; the measured number falls inside the stated range.
By their numbers in this assay, from the lowest: compounds 1 and 3 (each within the scatter of the next); then compound 2.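

In this assay, within the data shown here, this is the first measured single change at the aromatic nitrogen: putting 2-(trifluoromethyl)phenyl in place of benzyl gives a number 18 percentage points lower from compound 2 to compound 3 (beyond the scatter) in the read-out. The group on this nitrogen therefore matters, yet compound 3 still gives 77% at the one dose. Nothing measured here accounts for the fall. The change both removes the carbon linking the ring to the nitrogen and adds a trifluoromethyl group, and the compounds shown do not separate these two parts. A plain phenyl group on this nitrogen would help to tell them apart.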